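Halophenyl amides: expectation for compound 3

The source may hold more compounds than are shown below. What is called first, only, known or untested is meant among the compounds shown, and "the series" means these compounds.

- compound 1 `CN(C)C(=O)c1cc2cnc(Nc3ccc(NC(=O)C4(C(=O)Nc5ccc(F)cc5)CC4)cc3)nc2n1C1CCCC1`: 105%
- compound 2 `CN(C)C(=O)c1cc2cnc(Nc3ccc(NC(=O)C4(C(=O)Nc5ccc(Cl)cc5)CC4)cc3)nc2n1C1CCCC1`: 95%
- compound 3 `CN(C)C(=O)c1cc2cnc(Nc3ccc(NC(=O)C4(C(=O)Nc5cccc(F)c5)CC4)cc3)nc2n1C1CCCC1`: not yet measured

In a functional assay on T47D cells (Homo sapiens) for inhibition, read by CCK-8 assay, with a stated time of 72 h, tested at 10 uM (on this read-out higher numbers stand for more inhibition of growth at the one concentration tested and lower numbers for less inhibition of growth), compound 2 gives 95%, which lies within the scatter of compound 1 at 105%. The two measured compounds therefore cannot be ranked on this read-out.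

The change under review is 3-fluorophenyl in place of 4-chlorophenyl on an amide-type nitrogen. The shared core and the rest of the molecule stay the same.

Among the compounds with values here, only one measured step bears on this change: a number 10 percentage points lower from compound 1 to compound 2 (within the scatter), with chloro in place of fluoro on an aromatic carbon. That step stays within the scatter. Within the data shown here, no measured compound carries the 3-fluorophenyl group, so the data give no direct reading for it, and a single step is thin support.

In this assay the expected change is no shift beyond the scatter, and the estimated step is a number 1 percentage points higher from compound 2 to compound 3 (within the scatter). The estimate for compound 3 is 96%, with an expected range from 78% to 110%.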

Compound 3, percent growth inhibition at one concentration: -0.4%
For compound 3 the middle estimate is 96.4 percentage points above the measured one; the measured number lies below the stated range.
By their numbers in this assay, from the lowest: compound 3; then compounds 2 and 1 (each within the scatter of the next).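

In this assay the amide-type nitrogen turns out to be a sensitive place in the series: 3-fluorophenyl in place of 4-fluorophenyl, with the same halogen on the ring, gives a number 105.4 percentage points lower from compound 1 to compound 3 (beyond the scatter). 3-Fluorophenyl in place of 4-chlorophenyl gives a number 95.4 percentage points lower from compound 2 to compound 3 (beyond the scatter), whereas the earlier exchange of fluoro for chloro within the 4-halophenyl amides stayed at a number 10 percentage points lower from compound 1 to compound 2 (within the scatter), so that step gave no sign of how much the 3-fluorophenyl change would matter. Nothing at hand bears on why the 3-fluorophenyl amide behaves so differently from the two 4-halophenyl amides.

On these data alone, with a single 3-substituted compound, it remains open whether the drop belongs to fluoro at that place alone or extends to other groups there, and how an unsubstituted phenyl or a phenyl carrying a methoxy group or an amine would read. As far as these compounds go, since the read-out covers one concentration only, it also remains open whether compound 3 retains any growth inhibition at higher concentrations and how far compound 1 and compound 2 stand apart at lower concentrations.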